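From (chloromethyl)carbonyl to methyl on an amide-type nitrogen

The source may report more compounds than this note shows. Statements on the series, on what has been measured and on what is new or still open speak of the compounds shown alone.

Going by the values given here, compound 1 `CO[C@@H]1[C@H](OC(=O)NC(=O)CCl)CO[C@]2(COC(C)(C)O2)[C@@]1(O)C1(C)CO1` gives 84000 nM in a functional assay on A-431 cells (Homo sapiens) for antiproliferative activity (a lower number here means a stronger inhibitor, a higher number a weaker inhibitor), and so holds the highest number of the three measured so far. Compound 2 `CO[C@@H]1[C@H](OC(=O)NC(=O)CCl)CO[C@]2(COC(C)(C)O2)[C@@]1(OC)C1(C)CO1` stands at 39000 nM and compound 3 `CO[C@@H]1[C@H](OC(=O)NC(=O)CCl)CO[C@]2(COC(C)(C)O2)[C@@]1(OC(=O)CCl)C1(C)CO1` at 38000 nM after a new group goes onto an oxygen on a saturated carbon. Both changes give modest steps (a 2.2-fold lower number from compound 1 to compound 2 (0.33 log units; beyond the scatter) and a 2.2-fold lower number from compound 1 to compound 3 (0.34 log units; beyond the scatter)), and the two products do not differ beyond the scatter (a 1.0-fold lower number from compound 2 to compound 3 (0.01 log units; within the scatter)).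

Compound 4 `CNC(=O)O[C@@H]1CO[C@]2(COC(C)(C)O2)[C@@](O)(C2(C)CO2)[C@@H]1OC` changes a different place (methyl in place of (chloromethyl)carbonyl on an amide-type nitrogen) with methyl in place of (chloromethyl)carbonyl on an amide-type nitrogen. Among the compounds with values here, no measured step touches this nitrogen, so the data fix no direction and offer only a rough sense of size. Going by the modest steps to compound 2 and compound 3 (a 2.2-fold lower number from compound 1 to compound 2 (0.33 log units; beyond the scatter) and a 2.2-fold lower number from compound 1 to compound 3 (0.34 log units; beyond the scatter)), only a small shift is expected in this assay with wide uncertainty. The expected change is a 1.2-fold higher number from compound 1 to compound 4 (0.08 log units; within the scatter) and may well vanish in the scatter. Compound 4 is estimated at 100000 nM (expected range 30000 nM to 300000 nM).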

Compound 4, half-maximal inhibitory concentration: > 500000 nM
Compound 4 ended at the assay's limit; the forecaster's own chance of this, stated with the estimate: 30%; middle value at least 5.0-fold (0.69 log units) away from the limit.
By their numbers in this assay, from the lowest: compounds 3 and 2 (each within the scatter of the next); then compound 1. At a limit, above all of these: compound 4.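

Going by these compounds alone, the methyl in place of (chloromethyl)carbonyl on the amide-type nitrogen brings an at least 5.9-fold higher number from compound 1 to compound 4 (0.77 log units; beyond the scatter) and so shows that this nitrogen, which no earlier step touched, is a place where a change moves the number in this assay. The earlier steps on the oxygen lowered the number, while this one raises it, so among these compounds the (chloromethyl)carbonyl goes with the lower number, a link that rests on this single pair. Compound 4 stands at a limit of the assay and not at an exact number, which leaves the full size of the step unknown: the limit of > 500000 nM in this assay, at which 1 of the 4 values shown sits.

The compounds shown leave open whether the chlorine or the carbonyl of the departing group matters more. An acetyl group on this nitrogen would separate the two, and a longer chain would test how much room for change this place allows.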